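Bromo added to the shared core of compound 1

The compounds below may be only part of what the source reports. "The series", "measured", "known", "first", "only" and "open" are said of these compounds alone.

In a functional assay on SW-620 cells (Homo sapiens) (on this read-out higher numbers stand for weaker inhibition of growth and lower numbers for stronger inhibition of growth), compound 1 `O=S(=O)(/C=C/c1ccc(Br)cc1)Cc1ccc(Nc2ncnc3ccccc23)cc1` gives > 100000 nM, which is a limit and not a number. Compound 2 `O=S(=O)(/C=C/c1ccc(C(F)(F)F)cc1F)Cc1ccc(Nc2ncnc3ccccc23)cc1` reads 100000 nM. Within the data shown here, the one measured step, a number no higher from compound 1 to compound 2 (the limit leaves the size open), changes the group on the double-bonded chain carbon, and the limit leaves its size open. Compound 3 `O=S(=O)(/C=C/c1ccc(Br)cc1)Cc1ccc(Nc2ncnc3ccc(Br)cc23)cc1` instead carries bromo in place of hydrogen on an aromatic carbon of the fused system of two rings (bromo in place of hydrogen on an aromatic carbon). Among the measured compounds shown here, no measured step covers this site, so only a modest gain in growth inhibition is expected, as the step of an at least 1.6-fold lower number from compound 1 to compound 3 (0.22 log units; that floor lies within the scatter). Compound 3 is estimated at 60000 nM, with an expected range of 15000 nM to 100000 nM.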

Compound 3, concentration for 50% growth inhibition: > 100000 nM
Compound 3 gave a limit, no number; the forecaster's own chance of this, stated with the estimate: 50%; middle value at least 1.6-fold (0.22 log units) away from the limit.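

Compound 1 and compound 3 both give only a limit in this assay, so no step can be read between them: the limit of > 100000 nM in this assay, at which 2 of the 3 values shown sit.

As far as these compounds go, whether bromo in place of hydrogen on this aromatic carbon changes growth inhibition at all remains open.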